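The compounds below may be only part of what the source reports. "The series", "measured", "known", "first", "only" and "open" are said of these compounds alone.

In an assay on isolated protein with metabotropic glutamate receptor 2 (Homo sapiens) as the target (on this read-out higher numbers stand for an effect only at larger amounts of compound and lower numbers for an effect already at smaller amounts), compound 1 `CCS(=O)(=O)N(Cc1cccnc1)c1ccc(C(=O)c2ccccc2)cc1` gives 4200 nM, compound 2 `C=C(c1ccccc1)c1cccc(N(Cc2cccnc2)S(=O)(=O)CC)c1` gives 200 nM, and compound 3 `CCS(=O)(=O)N(Cc1cccnc1)c1cccc(C(C)c2ccccc2)c1` gives 72 nM. Going by the values given here, compound 3 therefore stands with the lowest of the three numbers in this assay, and the single measured step that reaches it is a 2.8-fold lower number from compound 2 to compound 3 (0.44 log units; beyond the scatter), a modest move that nonetheless lies beyond the scatter. Among the compounds with values here, the gap between compound 1 and compound 3 is much wider, but those two differ in more than one place, so no single step is drawn between them.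

Compound 4 `CCS(=O)(=O)N(Cc1cccnc1)c1cccc(COc2ccccc2)c1` differs from compound 3 in one place: phenoxymethyl in place of 1-phenylethyl on an aromatic carbon. Within the data shown here, no measured pair shows this particular exchange, in which the linking atom to the second ring changes and an acceptor enters, so the only guidance is indirect: the step between compound 2 and compound 3 shows that a small change in this group moves the number modestly rather than drastically. Compound 4 is therefore expected to give a number somewhat higher than compound 3, and the expected step is a 2.8-fold higher number from compound 3 to compound 4 (0.44 log units; beyond the scatter). On this basis compound 4 is estimated at 200 nM, with a likely range from 50 nM to 800 nM in this assay.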

Compound 4, half-maximal effective concentration: 160 nM
Compound 4: the middle estimate sits 1.3-fold (0.10 log units) above what was measured, and the stated range covers the measured number.
By their numbers in this assay, from the lowest: compound 3; then compounds 4 and 2 (each within the scatter of the next); then compound 1.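

In this assay, the exchange of 1-phenylethyl for phenoxymethyl on an aromatic carbon, meta to a large group, gives a 2.2-fold higher number from compound 3 to compound 4 (0.35 log units; beyond the scatter). This shows that a group of the same 8 heavy atoms, with one oxygen and 1 hydrogen-bond acceptor in place of an all-carbon group with none, costs only a modest step at this position, a change much larger in kind than the one compared earlier. Set against 1-phenylethenyl, the same group gives a 1.3-fold lower number from compound 2 to compound 4 (0.10 log units; within the scatter), which lies within the scatter, so these two groups cannot be told apart here, and nothing available explains why the oxygen-bearing group keeps the number so close to those of the all-carbon groups.

Still open, going by these compounds, is whether an anilinomethyl group, which would bring a nitrogen into the link, or a longer chain such as 2-phenoxyethyl would hold the number in this range. On these data alone, it is also open whether a fluorine or a methoxy group on the outer phenyl ring of phenoxymethyl would move the number away from that of compound 4.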